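Swapping a methoxy for a methyl on a weak scaffold

The source may hold more compounds than are shown below. What is called first, only, known or untested is meant among the compounds shown, and "the series" means these compounds.

Compound 1 `Cc1ccc(CNC(=O)c2cccc(C(C)Oc3cccnc3Nc3cnn(CC#N)c3)c2)cc1` gives 38400 nM in a functional assay on NCI-H3122 cells (Homo sapiens) for antiproliferative activity, read by MTT assay, with a stated time of 48 h; a lower number here means a stronger inhibitor, a higher number a weaker inhibitor. Compound 2 `COc1cccc(CNC(=O)c2cccc(C(C)Oc3ccnc(Nc4cnn(C)c4)c3)c2)c1` shows only > 100000 nM in this assay, and this is a limit of the measurement rather than a number (the limit of > 100000 nM in this assay, at which 1 of the 2 values shown sits). Compound 3 `Cc1ccc(CNC(=O)c2cccc(C(C)Oc3ccnc(Nc4cnn(C)c4)c3)c2)cc1` differs from compound 2 by 4-methylphenyl in place of 3-methoxyphenyl on a saturated chain carbon bound to an amide-type nitrogen. Going by the values given here, no measured pair shows this exact change, so the step from compound 2 to compound 3 in this assay is expected to be small, meaning an at least 1.2-fold lower number from compound 2 to compound 3 (0.09 log units; that floor lies within the scatter). Compound 3 is therefore estimated to give 80000 nM, within a range from 25000 nM to 200000 nM.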

Compound 3, half-maximal inhibitory concentration: 7700 nM
Compound 3: the middle estimate sits 10-fold (1.02 log units) above what was measured; measured number outside the range, below it.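

In this series, the group on the saturated chain carbon bound to an amide-type nitrogen matters: in this assay, replacing 3-methoxyphenyl with 4-methylphenyl gives an at least 12-fold lower number from compound 2 to compound 3 (1.11 log units; beyond the scatter). The earlier compounds shown here could not show this, as they differ in more than one place. The true size of the step stays unknown, since the entry for compound 2 is a limit of the assay and not a number: the limit of > 100000 nM in this assay, at which 1 of the 3 values shown sits.

Still open, as far as these compounds go, is whether the step follows the swap of methoxy for methyl or the different ring position of the group. A 3-methylphenyl or a 4-methoxyphenyl group would separate the two.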